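Compound 3: 2-fluorophenyl ester in the antiproliferative series

The source may report more compounds than this note shows. Statements on the series, on what has been measured and on what is new or still open speak of the compounds shown alone.

- compound 1 `CC(=O)O[C@H]1CC[C@]2(C)[C@H](CC[C@@](C)(O)[C@H]2CC[C@@H]2C(C)=CC[C@H]3[C@H](CC[C@]3(C)O)C2(C)C)OC1(C)C`: 47900 nM
- compound 2 `CC1=CC[C@H]2[C@H](CC[C@]2(C)O)C(C)(C)[C@@H]1CC[C@H]1[C@]2(C)CC[C@H](OC(=O)c3ccc(Cl)c(Cl)c3)C(C)(C)O[C@H]2CC[C@@]1(C)O`: 11900 nM

In a functional assay on MCF7 cells (Homo sapiens) for antiproliferative activity, read by MTT assay, with a stated time of 72 h (a lower number here means a stronger inhibitor, a higher number a weaker inhibitor), compound 2 has the lower of the two numbers, 11900 nM. The next compound is compound 3 `CC1=CC[C@H]2[C@H](CC[C@]2(C)O)C(C)(C)[C@@H]1CC[C@H]1[C@]2(C)CC[C@H](OC(=O)c3ccccc3F)C(C)(C)O[C@H]2CC[C@@]1(C)O`, with 2-fluorophenyl in place of 3,4-dichlorophenyl on a carbonyl carbon. Going by the values given here, the one measured step that bears on this is a 4.0-fold lower number from compound 1 to compound 2 (0.60 log units; beyond the scatter), with 3,4-dichlorophenyl in place of methyl. Among the compounds with values here, compound 3 keeps an aromatic ring, but no measured compound carries fluorine. Most of that drop is expected to remain, so no step beyond the scatter is expected, with a slight lean towards a higher number. The expected step is a 1.5-fold higher number from compound 2 to compound 3 (0.18 log units; within the scatter). The estimate for compound 3 is 18000 nM, with an expected range of 8000 nM to 40000 nM.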

Compound 3, half-maximal inhibitory concentration: 11300 nM
Compound 3: middle estimate off by 1.6-fold (0.20 log units), on the high side; the range from low to high includes it.
By their numbers in this assay, from the lowest: compounds 3 and 2 (each within the scatter of the next); then compound 1.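

In this assay, 2-fluorophenyl on the carbonyl carbon gives a 1.1-fold lower number from compound 2 to compound 3 (0.02 log units; within the scatter), so this position does not separate these two halogen-bearing aromatic esters. Against methyl at the same place, the second aromatic ester gives a 4.2-fold lower number from compound 1 to compound 3 (0.63 log units; beyond the scatter), which shows that the step beyond the scatter holds for compound 2 and compound 3 alike, not for the 3,4-dichlorophenyl group alone. No measured evidence accounts for this result.

Open, from the compounds shown here alone, is whether a halogen is needed at all, as an unsubstituted phenyl would show. Also open, going by these compounds, is how a longer alkyl chain or a pyridine ring would compare at this place.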